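A few compounds are considered here, and "the series" means these few. Any claim that something is new, unique, unknown or untested is made for them only; others in the source may bear on it.

Working notes on the series, all read in a functional assay on CCRF-CEM cells (Homo sapiens) for inhibition; on this read-out higher numbers stand for weaker inhibition and lower numbers for stronger inhibition:

- compound 1 `O=C1CCCCC/C1=C\c1ccc(F)cc1`: 198000 nM
- compound 2 `O=C1CCCCC/C1=C\c1ccc(Cl)cc1`: 43500 nM
- compound 3 `Cc1ccc(/C=C2\CCCCCC2=O)cc1`: > 500000 nM (a limit of the assay, not a number)

Compound 3 has no measured number on this read-out, only the limit > 500000 nM. Any step starting from compound 3 is therefore bounded on one side only.

Compound 4 `COc1ccc(/C=C2\CCCCCC2=O)cc1` carries methoxy in place of methyl on an aromatic carbon. Going by the values given here, three measured steps concern this same place on the shared core: a 4.6-fold lower number from compound 1 to compound 2 (0.66 log units; beyond the scatter), an at least 2.5-fold higher number from compound 1 to compound 3 (0.40 log units; beyond the scatter) and an at least 11-fold higher number from compound 2 to compound 3 (1.06 log units; beyond the scatter). All three lie beyond the scatter, so changes at this place do register in this assay. None of them involves methoxy, which leaves their size only a loose guide.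

The expectation is a modest move towards a lower number, with compound 4 staying in the high range set by compound 1 at 198000 nM. A result reported only as a limit remains quite possible. The expected size of the change is an at least 1.6-fold lower number from compound 3 to compound 4 (0.22 log units; that floor lies within the scatter). For compound 4 the estimated value is 300000 nM, with an expected range of 90000 nM to 700000 nM.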

Compound 4, half-maximal inhibitory concentration: 194000 nM
For compound 4 the middle estimate is 1.5-fold (0.19 log units) above the measured one, within the range that was stated.
By their numbers in this assay, from the lowest: compound 2; then compounds 4 and 1 (each within the scatter of the next). At a limit, above all of these: compound 3.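

In this assay, going by these compounds alone, methoxy in place of methyl gives an at least 2.5-fold lower number from compound 3 to compound 4 (0.41 log units; beyond the scatter), the first step at this place that leads away from the limit and onto a measured number. Compound 3 is held only by a limit, so this step has a floor and no measured size: the limit of > 500000 nM in this assay, at which 1 of the 4 values shown sits. Methoxy in place of fluoro gives a 1.0-fold lower number from compound 1 to compound 4 (0.01 log units; within the scatter), so these two groups are not told apart on this read-out, whereas methoxy in place of chloro gives a 4.5-fold higher number from compound 2 to compound 4 (0.65 log units; beyond the scatter), which leaves compound 2 the strongest of the four, with chloro the only group here whose steps to all the others lie beyond the scatter.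

The compounds shown cover only four small groups at this one place, so an amine, a carboxylic acid or a longer chain such as ethoxy on the same aromatic carbon remains unplaced against compound 2. They also leave open whether any group at this place can move the number well past that of compound 2, and what sets chloro apart from fluoro, methyl and methoxy.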